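Neopentyl at the chain carbon: compound 3 to compound 4

The source may report more compounds than this note shows. Statements on the series, on what has been measured and on what is new or still open speak of the compounds shown alone.

Compound 3 `CC[C@H](C)[C@H](NC(=O)[C@H](CC(C)C)[C@H](C)N(O)C=O)C(=O)Nc1nccs1` gives 29 nM in an assay on isolated protein for inhibition of matrix metalloproteinase-9 (Homo sapiens); a higher number here means a weaker inhibitor, a lower number a stronger inhibitor. Its number sits with those of compound 1 `CC(C)C[C@@H](C(=O)N[C@H](C(N)=O)C(C)(C)C)[C@H](C)N(O)C=O`, which gives 33 nM, and compound 2 `CC(C)C[C@@H](C(=O)N[C@H](C(=O)Nc1nccs1)C(C)(C)C)[C@H](C)N(O)C=O`, which gives 34 nM, all within the scatter of one another. Compound 4 `CC(C)C[C@@H](C(=O)N[C@@H](CC(C)(C)C)C(=O)Nc1nccs1)[C@H](C)N(O)C=O` differs from compound 3 by neopentyl in place of sec-butyl on a saturated chain carbon bound to an amide-type nitrogen and a carbonyl carbon. The step that bears on it most is the change at the same carbon, a 1.2-fold lower number from compound 2 to compound 3 (0.07 log units; within the scatter); the other change in the set, a 1.0-fold higher number from compound 1 to compound 2 (0.01 log units; within the scatter), also stayed within the scatter. Since neither alteration moved the inhibition constant, a further change at that carbon is expected to give no step beyond the scatter, a 1.2-fold higher number from compound 3 to compound 4 (0.08 log units; within the scatter). Compound 4 is therefore estimated at 35 nM, with a range of 15 nM to 80 nM.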

Compound 4, inhibition constant: 98 nM
Compound 4: middle estimate off by 2.8-fold (0.45 log units), on the low side, outside the stated range (above it).
By their numbers in this assay, from the lowest: compounds 3, 1 and 2 (each within the scatter of the next); then compound 4.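

At this chain carbon, bound to an amide-type nitrogen and a carbonyl carbon, the group present can change the number in this assay: neopentyl in place of sec-butyl gives a 3.4-fold higher number from compound 3 to compound 4 (0.53 log units; beyond the scatter), and neopentyl in place of tert-butyl gives a 2.9-fold higher number from compound 2 to compound 4 (0.46 log units; beyond the scatter), both beyond the scatter. The earlier insensitivity at this carbon therefore held for tert-butyl and sec-butyl but does not extend to neopentyl. Nothing available here accounts for this step. As far as these compounds go, whether an unbranched butyl chain, an amine or a carboxylic acid at this carbon would stay with sec-butyl or move as neopentyl does remains open.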